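Acyl group change from compound 2 to compound 3

The source may hold more compounds than are shown below. What is called first, only, known or untested is meant among the compounds shown, and "the series" means these compounds.

Compound 1 `CC(C)CCC(=O)N[C@@H](C(=O)N1CCC(c2ccc(Cl)cc2)CC1)C(C)C` gives 26 nM in an assay on THP-1 cells for displacement of a labelled ligand from C-C chemokine receptor type 1 (Homo sapiens); on this read-out higher numbers stand for weaker inhibition and lower numbers for stronger inhibition. Compound 2 `CC(C)[C@@H](NC(=O)c1cc2ccccc2s1)C(=O)N1CCC(c2ccc(Cl)cc2)CC1` gives 58 nM in this assay and stands highest of the two numbers; the step of a 2.2-fold higher number from compound 1 to compound 2 (0.35 log units; beyond the scatter) is the only one measured so far. Compound 3 `CC(C)[C@@H](NC(=O)c1ccc(F)c(F)c1)C(=O)N1CCC(c2ccc(Cl)cc2)CC1` carries 3,4-difluorophenyl in place of 1-benzothiophen-2-yl on a carbonyl carbon. Among the compounds with values here, only the step from compound 1 to compound 2 bears on this change, since it altered the group on the same carbonyl carbon, and it was modest; an aryl to aryl exchange here has no measured precedent. For compound 3 a step of about a 1.0-fold higher number from compound 2 to compound 3 (0.01 log units; within the scatter) is expected, within the scatter. The estimate for compound 3 is 60 nM, with a range of 20 nM to 180 nM.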

Compound 3, half-maximal inhibitory concentration: 14 nM
Compound 3: middle estimate off by 4.3-fold (0.63 log units), on the high side; measured number below the stated range.
By their numbers in this assay, from the lowest: compounds 3 and 1 (each within the scatter of the next); then compound 2.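

At this carbonyl carbon, one aryl group cannot stand in for another in this assay: the exchange gives a 4.1-fold lower number from compound 2 to compound 3 (0.62 log units; beyond the scatter). An aryl group also need not lose ground to the open chain, since the change from isopentyl to 3,4-difluorophenyl gives a 1.9-fold lower number from compound 1 to compound 3 (0.27 log units; within the scatter). Nothing measured here accounts for the gap between the two aryl groups.

Still open, from the compounds shown here alone, is whether the fluorines contribute at all, which plain phenyl would test. Also open, going by these compounds, is how this carbonyl carbon tolerates a pyridyl group or a phenyl carrying a carboxylic acid.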